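A few compounds are considered here, and "the series" means these few. Any claim that something is new, unique, unknown or untested is made for them only; others in the source may bear on it.

Measured so far:
compound 1, `N=C(N)c1ccc(-c2ccc(-c3cc(Cl)cc(Cl)c3)s2)s1`: 1670 nM
compound 2, `COc1ccc(-c2ccc(-c3ccc(C(=N)N)o3)o2)cc1`: 290 nM
compound 3, `N=C(N)c1ccc(-c2ccc(-c3ccc(Cl)cc3)s2)s1`: 1640 nM

In a functional assay on MDA-MB-435 cells (Homo sapiens) for inhibition, read by sulforhodamine B assay, with a stated time of 48 h (a lower number here means a stronger inhibitor of growth, a higher number a weaker inhibitor of growth), compound 2 stands lowest of the three numbers. Compound 3 and compound 1 both lie beyond the usual scatter above it, while those two are within the scatter of each other. Among the compounds with values here, compound 1 and compound 3 share a core that is not the core of compound 2, so no measured pair differs in one place only, and no measured step is at hand to calibrate a single change.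

Compound 4, `N=C(N)c1ccc(-c2ccc(-c3ccccc3)o2)o1`, keeps the core of compound 2 and differs from it in one place: hydrogen in place of methoxy on an aromatic carbon. Nothing measured shows what this change does on this core. The expectation is a modest rise in the number, of a size that may or may not clear the scatter; the expected step is a 1.7-fold higher number from compound 2 to compound 4 (0.24 log units; within the scatter). Compound 4 is estimated at 500 nM, with a range from 200 nM to 1500 nM, pending measurement in this assay.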

Compound 4, concentration for 50% growth inhibition: 990 nM
Estimate against measurement, compound 4: 2.0-fold (0.30 log units) below, and the stated range covers the measured number.
By their numbers in this assay, from the lowest: compound 2; then compounds 4, 3 and 1 (each within the scatter of the next).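

In this assay, within the data shown here, hydrogen in place of methoxy gives a 3.4-fold higher number from compound 2 to compound 4 (0.53 log units; beyond the scatter) and is the first single change that can be read. The position on the six-membered aromatic ring of carbon only, para to a large group, is therefore not silent on this core: the number depends on what sits there, and the compound carrying methoxy is the stronger inhibitor of growth of this pair. Nothing on hand explains the size of this step or ties it to any property of the methoxy group.

Going by these compounds, whether an amine, a hydroxyl or an ethoxy group at this position would give a number nearer that of compound 2 or that of compound 4 stays open. Also open, on these data alone, is whether a change at this position would give a step of like size on the core of compound 1 and compound 3.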